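Carrying One Chloro Substitution From One Core to Another

The source may hold more compounds than are shown below. What is called first, only, known or untested is meant among the compounds shown, and "the series" means these compounds.

Measured so far in a functional assay on HCT-116 cells (Homo sapiens) for antiproliferative activity, read by CCK-8 assay, with a stated time of 72 h, tested at 8 uM; on this read-out lower numbers stand for a weaker effect and higher numbers for a stronger effect at the one concentration tested:
compound 1, `Nc1ccccc1NC(=O)c1ccc(Cn2cnc3c(Nc4ccccc4)nc(Cl)nc32)cc1`: compound 1 gives 83.5%
compound 2, `CCCCn1cnc2c(Nc3ccccc3)nc(NCOCc3ccc(C(=O)Nc4ccccc4N)cc3)nc21`: compound 2 gives 74.9%
compound 3, `Nc1ccccc1NC(=O)c1ccc(Cn2cnc3c(Nc4cccc(Cl)c4)nc(Cl)nc32)cc1`: compound 3 gives 78.4%

The account concerns a single structural change and the question of whether it carries over from one core to another. Compound 1 and compound 3 share a core and differ only by chloro in place of hydrogen on an aromatic carbon. In this assay this change gave a number 5.1 percentage points lower from compound 1 to compound 3 (within the scatter), so the two read-outs sit close together and no direction can be read from them.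

Compound 2 carries a different core; how it differs from compound 1 is not broken down here. Its value in this assay lies close to those of compound 1 and compound 3, all three within the usual scatter of one another.

Compound 4, `CCCCn1cnc2c(Nc3cccc(Cl)c3)nc(NCOCc3ccc(C(=O)Nc4ccccc4N)cc3)nc21`, is not yet measured. It differs from compound 2 by chloro in place of hydrogen on an aromatic carbon, the same change as that from compound 1 to compound 3, at a place described in the same words. Going by the values given here, the only guide is the step already seen, a number 5.1 percentage points lower from compound 1 to compound 3 (within the scatter), which was small. On that basis the author expects a similarly small step, a number 3.9 percentage points lower from compound 2 to compound 4 (within the scatter). For compound 4 in this assay the author therefore estimates 71%, most likely between 58% and 82%.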

Compound 4, a percentage reported as inhibition, at one concentration (the size of the read-out at that concentration, not a potency): 71.9%
For compound 4 the middle estimate is 0.9 percentage points below the measured one, within the range that was stated.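

In this assay, putting chloro in place of hydrogen on an aromatic carbon, which turns the phenyl of the anilino group into 3-chlorophenyl, gave a number 3 percentage points lower from compound 2 to compound 4 (within the scatter) on the core of compound 2. Set beside the earlier step, the change reads alike on both cores: the same change on two cores in this assay, a number 5.1 percentage points lower (within the scatter) from compound 1 to compound 3 and a number 3 percentage points lower (within the scatter) from compound 2 to compound 4, 2.1 percentage points apart, within the scatter of two such steps

This shows that on these two cores the change left the read-out within the usual scatter, but since both steps are that small, it does not show a true direction for the change, nor that a real effect of chloro has carried from one core to the other, and two cores at a single concentration say nothing about potency or about any further core.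

The compounds shown leave open whether another group on the same aromatic ring, such as a methoxy group, an amine or a carboxylic acid, would produce a step beyond the scatter and whether that step would then match on both cores. They also leave open how the chloro step would read on the core of compound 2 if a longer chain stood in place of its butyl chain.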